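Adding a third methoxy to the benzyl series

The source may hold more compounds than are shown below. What is called first, only, known or untested is meant among the compounds shown, and "the series" means these compounds.

Compound 1 `COc1ccccc1CNc1ncnc2c1ncn2C1CCCCO1` gives 97000 nM
Compound 2 `COc1ccc(CNc2ncnc3c2ncn3C2CCCCO2)c(OC)c1` gives the limit > 25000 nM
Compound 3 `COc1cccc(OC)c1CNc1ncnc2c1ncn2C1CCCCO1` gives 10300 nM

In an ADME assay on K562 cells (Homo sapiens) for cytotoxicity, with a stated time of 72 h (on this read-out higher numbers stand for weaker inhibition and lower numbers for stronger inhibition), compound 3 gives 10300 nM and holds the lower of the two readable numbers. Compound 2 is reported only as a limit and cannot be ranked with them.

Compound 4 `COc1cc(OC)c(CNc2ncnc3c2ncn3C2CCCCO2)c(OC)c1` is not yet measured. Its difference from compound 3 is methoxy in place of hydrogen on an aromatic carbon and amounts to methoxy in place of hydrogen on an aromatic carbon, meta to two methoxy groups and para to a large group.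

Two measured steps are the same kind of replacement. One is a 9.4-fold lower number from compound 1 to compound 3 (0.97 log units; beyond the scatter) and the other is a step that the limit leaves unreadable from compound 1 to compound 2 so only one size can be read. A single readable step, made on a different starting compound, gives no firm direction for a further methoxy. In this assay no change beyond the scatter is therefore expected, though with a wide margin on either side. The expected step is a 1.4-fold higher number from compound 3 to compound 4 (0.13 log units; within the scatter) and this remains an estimate only. Compound 4 is estimated at 14000 nM with an expected range from 4000 nM to 45000 nM in this read-out.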

Compound 4, half-maximal inhibitory concentration: > 50000 nM
Compound 4: no number, only a limit; the forecaster's own chance of this, stated with the estimate: 25%; middle value at least 3.5-fold (0.55 log units) away from the limit.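

In this assay compound 4 is reported only as a limit, not as a number: the limit of > 50000 nM in this assay, at which 1 of the 4 values shown sits.
Even so, the step can be read in one direction, an at least 4.8-fold higher number from compound 3 to compound 4 (0.68 log units; beyond the scatter), so a methoxy in place of hydrogen on the aromatic carbon meta to two methoxy groups and para to a large group goes with a higher number on this read-out.
The only other readable replacement of this kind, a 9.4-fold lower number from compound 1 to compound 3 (0.97 log units; beyond the scatter), runs the opposite way, so among the compounds shown methoxy in place of hydrogen has no single direction, and the outcome differs with the starting compound and the carbon that takes the group.

The steps from compound 1 to compound 2 and from compound 2 to compound 4 cannot be read, and the data do not tell how far the number of compound 4 lies past its limit or what lies behind the reversal in direction.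
Also open, as far as these compounds go, is whether a group other than methoxy on this same aromatic carbon, such as an amine, a carboxylic acid or a longer chain on the oxygen, would keep the number of compound 3 or move it.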